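The source may hold more compounds than are shown below. What is called first, only, known or untested is meant among the compounds shown, and "the series" means these compounds.

Measured compounds:
- compound 2, `O=S(=O)(c1ccccc1)c1cn(C2CCNC2)c2ccccc12`: 5 nM
- compound 1, `CN1CCCC(n2cc(S(=O)(=O)c3cccc4ccccc34)c3ccccc32)C1`: 7.1 nM

In an assay on HeLa cells for displacement of a labelled ligand from 5-hydroxytryptamine receptor 6 (Homo sapiens), with a stated time of 2 h (a lower number here means a stronger inhibitor, a higher number a weaker inhibitor), compound 2 gives 5 nM, the lowest of the two numbers in hand. Its nearest neighbour is compound 1 at 7.1 nM; the gap between the two lies within the scatter, so the two numbers cannot be told apart. The two compounds share the core seen in compound 2 and differ in the ring carrying the amine and in the aromatic group on the sulfone, so no single-point comparison exists between them.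

Compound 3, `O=S(=O)(c1ccccc1)c1cn(C2CCN(Cc3ccccc3)C2)c2ccccc12`, is not yet measured. It differs from compound 2 in one place: benzyl in place of hydrogen on an amine nitrogen in a ring. Within the data shown here, no measured pair shows this change, so its effect is not known from the series. A modest weakening is expected rather than none, given that the two measured amines both carry at most a small group on the nitrogen.

The expected step of a 3.0-fold higher number from compound 2 to compound 3 (0.48 log units; beyond the scatter) is small to moderate, toward a higher number. For compound 3 the estimate in this assay is 15 nM, with a range from 4 nM to 60 nM.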

Compound 3, inhibition constant: 113 nM
The estimate for compound 3 lay 7.5-fold (0.88 log units) below the measured number; the measured number lies above the stated range.
By their numbers in this assay, from the lowest: compounds 2 and 1 (each within the scatter of the next); then compound 3.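

In this assay, among these compounds, putting benzyl in place of hydrogen on the amine nitrogen of the five-membered non-aromatic ring gives a 23-fold higher number from compound 2 to compound 3 (1.35 log units; beyond the scatter) and is the only single-place change read so far. This position therefore does not tolerate every substituent: the added benzyl, with its six-membered aromatic ring of carbon only, costs a large share of the binding seen for the unsubstituted amine. The data offer no explanation for the size of this step.

An ethyl, a phenethyl chain or an acetyl on the same nitrogen would show whether the loss follows from the aromatic ring, the chain or any group at all on this nitrogen. From the compounds shown here alone, whether the step carries over to a six-membered amine ring or to a naphthyl group on the sulfone also remains open.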